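A Four-Membered Ring Replaces Ethyl on the Core

This account rests on a few compounds, and the source may have more. Where it says the series, first, only, none or still open, it means among the compounds named here.

Compound 1 `CCC(C)(C)C1CCc2c(sc(NC(=O)Nc3ccc(Cl)cc3)c2C(N)=O)C1`: > 25000 nM
Compound 2 `CCC1CCc2c(sc(NC(=O)Nc3ccc(Cl)cc3)c2C(N)=O)C1`: > 25000 nM
Compound 3 `CCN1CCc2c(sc(NC(=O)Nc3ccc(Cl)cc3Cl)c2C(N)=O)C1`: 11500 nM

In a functional assay (strain AB) with Danio rerio as the target, read by microscopy, with a stated time of 1 h (a lower number here means that less compound is needed, a higher number that more compound is needed for the effect), compound 2 gives > 25000 nM, which is a limit of the assay and not a number. Compound 1 likewise sits at the limit of > 25000 nM in this assay, at which 2 of the 3 values shown sit. Compound 3, which differs at several places, gives 11500 nM. Compound 4 `C[N+]1(C2CCc3c(sc(NC(=O)Nc4ccc(Cl)cc4)c3C(N)=O)C2)CCC1` is not yet measured; it differs from compound 2 by a group of 5 heavy atoms (4 carbon, 1 nitrogen; one four-membered non-aromatic ring with 1 hetero atom) in place of a group of 2 heavy atoms (2 carbon; no ring), on a saturated ring carbon. For the measured compounds named here, the only single-place step measured, a step that the two limits leave unreadable from compound 1 to compound 2, is unreadable, so no step bears on the change to compound 4. Compound 2 stands at the limit, and compound 4 is expected to stay near it, with an estimated step that the limit leaves unreadable from compound 2 to compound 4. Compound 4 is thus estimated at 30000 nM, within 8000 nM to 120000 nM.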

Compound 4, half-maximal effective concentration: 3920 nM
Compound 4: the middle estimate sits 7.7-fold (0.88 log units) above what was measured; measured number outside the range, below it.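

Before compound 4, this saturated ring carbon gave no readable step, because compound 1 and compound 2 both sit at a limit of the assay: the limit of > 25000 nM in this assay, at which 2 of the 4 values shown sit. In this assay, for the compounds shown here, the four-membered ring with its net charge of +1 gives the first readable change here, with an at least 6.3-fold lower number from compound 2 to compound 4 (0.80 log units; beyond the scatter) and an at least 6.3-fold lower number from compound 1 to compound 4 (0.80 log units; beyond the scatter). From the compounds shown here alone, the number at this position can therefore move with the group placed on it, and the true size of each step stays unknown.

Going by these compounds, whether the change follows the ring or the net charge remains open, and an uncharged azetidine or a dimethylamino group on this carbon would bear on that question.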